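The compounds below may be only part of what the source reports. "The series", "measured", "known", "first", "only" and "open" are said of these compounds alone.

Measured compounds:
compound 1 `Nc1ccccc1NC(=O)c1ccc(CSC(=S)N2CCc3cc(Cl)ccc32)cc1` — 82.2%
compound 2 `Cc1ccc(N2CCN(C(=S)SCc3ccc(C(=O)Nc4ccccc4N)cc3)CC2)cc1` — 19.8%

In a functional assay on MGC-803 cells (Homo sapiens) for antiproliferative activity, read by CCK-8 assay, with a stated time of 72 h, tested at 8 uM (a lower number here means a weaker effect, a higher number a stronger effect of the compound at the concentration tested), compound 1 gives 82.2%, the higher of the two numbers in hand; compound 2 gives 19.8%, a gap that lies beyond the scatter. For the measured compounds named here, no pair that differs in only one place has been measured, so no step size can be read from the data.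

Compound 3 `Nc1ccccc1NC(=O)c1ccc(CSC(=S)N2CCCC2)cc1` has not been measured. It differs from compound 1 by pyrrolidin-1-yl in place of 5-chloro-2,3-dihydro-1H-indol-1-yl on a thiocarbonyl carbon. Only the two values above are available to judge this change, and neither pairing isolates it. Given that the ring that enters is smaller than the one that leaves, and that the only other variant of this position, compound 2, sits far lower at 19.8%, a drop in this assay is expected, of a size beyond the scatter; the step from compound 1 to compound 3 is estimated as a number 27.2 percentage points lower from compound 1 to compound 3 (beyond the scatter). Compound 3 is expected to give about 55%, with a likely range from 25% to 80%.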

Compound 3, a percentage reported as inhibition, at one concentration (the size of the read-out at that concentration, not a potency): 83.4%
The estimate for compound 3 lay 28.4 percentage points below the measured number, and the stated range ends below it.
By their numbers in this assay, from the lowest: compound 2; then compounds 1 and 3 (each within the scatter of the next).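

The step of a number 1.2 percentage points higher from compound 1 to compound 3 (within the scatter) in this assay shows that the aromatic ring and the chlorine of 5-chloro-2,3-dihydro-1H-indol-1-yl are not needed for a high read-out on this thiocarbonyl carbon, since pyrrolidin-1-yl alone keeps it there. The position is still not indifferent to the group it carries: compound 2 stands at 19.8% in this assay, so the tolerance seen with compound 3 does not extend to every ring. Nothing at hand explains why these groups behave as they do.

Open, as far as these compounds go, is whether piperidin-1-yl, morpholin-4-yl or an open-chain diethylamino group on the same carbon would hold the read-out. Also open, from the compounds shown here alone, is whether compound 1 and compound 3 would separate in potency, given that a single concentration cannot show this.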